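The source may hold more compounds than are shown below. What is called first, only, known or untested is meant among the compounds shown, and "the series" means these compounds.

Measured compounds in a functional assay on PANC-1 cells (Homo sapiens) for inhibition, read by MTT assay, with a stated time of 24 h; on this read-out lower numbers stand for stronger inhibition and higher numbers for weaker inhibition:
- compound 1, `Cc1ccccc1-n1cc(CN2C(=O)C[C@@H]3CC[C@@]2(C)C3(C)C)nn1`: 250 nM
- compound 2, `COc1ccccc1-n1cc(CN2C(=O)C[C@@H]3CC[C@@]2(C)C3(C)C)nn1`: 120 nM
- compound 3, `CC1(C)[C@H]2CC[C@]1(C)N(Cc1cn(-c3ccccc3)nn1)C(=O)C2`: 160 nM

Compound 2 gives the lowest of the three numbers in this assay. Its gap to compound 3 is a 1.3-fold higher number from compound 2 to compound 3 (0.12 log units; within the scatter), so on these numbers the two are not separable. The step of a 2.1-fold lower number from compound 1 to compound 2 (0.32 log units; beyond the scatter) does stand out, while the step of a 1.6-fold lower number from compound 1 to compound 3 (0.19 log units; within the scatter) does not. All three differ only in what sits on the aromatic nitrogen of the five-membered aromatic ring with 3 nitrogen; the shared core is otherwise unchanged.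

Compound 4, `CC1(C)[C@H]2CC[C@]1(C)N(Cc1cn(-c3cccc(F)c3)nn1)C(=O)C2`, is not yet measured. The change from compound 2 is 3-fluorophenyl in place of 2-methoxyphenyl on an aromatic nitrogen

For the measured compounds named here, the steps that bear on this are the small ones among compounds 1, 2 and 3: exchanges of the group on this phenyl ring have so far moved the number by at most a 2.1-fold lower number from compound 1 to compound 2 (0.32 log units; beyond the scatter) and otherwise stayed within the scatter. Going by the values given here, no measured pair carries a fluorine, and none places the substituent where compound 4 does, so the expectation rests only on how little the phenyl variation has mattered so far. The expected step from compound 2 to compound 4 is a 1.4-fold higher number from compound 2 to compound 4 (0.15 log units; within the scatter), that is, no change beyond the scatter, with a slight lean toward a higher number because compound 3 without any substituent gave 160 nM. Compound 4 is therefore estimated at 170 nM in this assay, within 80 nM to 350 nM.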

Compound 4, half-maximal inhibitory concentration: 220 nM
Compound 4: middle estimate off by 1.3-fold (0.11 log units), on the low side, within the range that was stated.
By their numbers in this assay, from the lowest: compounds 2, 3, 4 and 1 (each within the scatter of the next, the first and the last beyond it).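

Fluoro on the phenyl ring is new to the series, and in this assay it gives no separation from the unsubstituted phenyl (a 1.4-fold higher number from compound 3 to compound 4 (0.14 log units; within the scatter)). The 3-fluorophenyl group is also not separable from either 2-substituted phenyl, whether 2-methoxyphenyl (a 1.8-fold higher number from compound 2 to compound 4 (0.26 log units; within the scatter)) or 2-methylphenyl (a 1.1-fold lower number from compound 1 to compound 4 (0.06 log units; within the scatter)), so compound 4 shows that a different substituent at a different place on this ring, still on the aromatic nitrogen of the five-membered ring, can be accommodated without a step beyond the scatter; in those two steps, however, the kind of substituent and its place on the ring change together and cannot be told apart. No supporting data are available that could account for these small differences, and the numbers alone offer no explanation.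

Still open, going by these compounds, is whether any group on this phenyl ring moves the number well beyond the scatter, for example an amine, a carboxylic acid or a longer alkyl chain in place of the fluoro. Also open, on these data alone, is how methoxy and fluoro compare when carried on the same ring carbon, and whether changes away from this ring, in the shared core or the linking methylene, matter more.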